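Swapping furan for thiophene beside the pyridine nitrogen

This account rests on a few compounds, and the source may have more. Where it says the series, first, only, none or still open, it means among the compounds named here.

Measured compounds:
Compound 1 `Oc1cccc(-c2cc(-c3cccc(Cl)c3)nc(-c3ccccn3)c2)c1` — "not determined" (no result reported) in a functional assay on DU-145 cells (Homo sapiens) for cytotoxicity, read by CCK-8 assay and cell counting, with a stated time of 2 days; a lower number here means a stronger inhibitor, a higher number a weaker inhibitor
Compound 2 `Oc1cccc(-c2cc(-c3cccc(Cl)c3)nc(-c3ccco3)c2)c1` — 2020 nM
Compound 3 `Oc1cccc(-c2cc(-c3ccc(Cl)cc3)nc(-c3ccco3)c2)c1` — 11400 nM

Three analogues sharing one core have been examined so far. For compound 1 the entry in this assay reads "not determined" (no result reported). Compound 2 gives the lowest of the two numbers available; the nearest entry is compound 3, and the step of a 5.6-fold higher number from compound 2 to compound 3 (0.75 log units; beyond the scatter) arises from a 4-chlorophenyl in place of a 3-chlorophenyl on an aromatic carbon, a change on a different part of the core.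

The next compound, compound 4 `Oc1cccc(-c2cc(-c3cccc(Cl)c3)nc(-c3cccs3)c2)c1`, keeps the 3-chlorophenyl group of compound 2 and changes only the five-membered ring next to the ring nitrogen: thiophen-2-yl in place of furan-2-yl on an aromatic carbon. Within the data shown here, no measured step touches this position, so the only guidance is that the one step recorded, from a chlorophenyl shift, was modest in size. Exchanging one five-membered aromatic ring with one hetero atom for another of the same size and acceptor count is taken here as a change of smaller consequence than that.

Compound 4 is therefore expected to stay close to compound 2, with the step of a 1.1-fold lower number from compound 2 to compound 4 (0.05 log units; within the scatter) predicted to lie within the scatter. The estimate for compound 4 in this assay is 1800 nM, with a range from 700 nM to 5000 nM.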

Compound 4, half-maximal inhibitory concentration: 2650 nM
Beside the measured number, compound 4's estimate is 1.5-fold (0.17 log units) below it, within the range that was stated.
By their numbers in this assay, from the lowest: compounds 2 and 4 (each within the scatter of the next); then compound 3.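

In this assay, among these compounds, the first measured change at the place next to the ring nitrogen, thiophen-2-yl in place of furan-2-yl, gives a 1.3-fold higher number from compound 2 to compound 4 (0.12 log units; within the scatter) and so leaves the number within the scatter, which shows that the two five-membered rings cannot be told apart here. The only earlier step, a 5.6-fold higher number from compound 2 to compound 3 (0.75 log units; beyond the scatter), came from 4-chlorophenyl in place of 3-chlorophenyl, so among these compounds the chlorophenyl change registers in this assay while the exchange of ring oxygen for ring sulfur does not. Nothing available accounts for either outcome, so the closeness of the furan-2-yl and thiophen-2-yl compounds remains an observation without an explanation.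

Going by these compounds, both groups compared at this place are five-membered aromatic rings with one hetero atom, and compound 1 has no number to compare, so it remains open whether the place would accept something quite different, such as an amine, a carboxylic acid or a longer alkyl chain. On these data alone, it is also open whether 4-chlorophenyl would give a similar step alongside thiophen-2-yl as it does alongside furan-2-yl.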